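Oxadiazole to isoxazole swap at the amide carbonyl

The source may report more compounds than this note shows. Statements on the series, on what has been measured and on what is new or still open speak of the compounds shown alone.

Measured so far:
compound 1 `COc1cc2nccc(Oc3ccc(NC(=O)c4nnc(-c5ccc(F)cc5)o4)cc3)c2cc1OC` — 5140 nM
compound 2 `COc1cc2c(Oc3ccc(NC(=O)C4(c5nnc(-c6ccc(F)cc6)o5)CC4)cc3F)ccnc2cc1OCCCN1CCC(C)CC1` — 120 nM
compound 3 `COc1cc2c(Oc3ccc(NC(=O)c4ncc(-c5ccc(F)cc5)o4)cc3)ccnc2cc1OCCCN1CCC(C)CC1` — 240 nM

In a functional assay on A549 cells (Homo sapiens) for antiproliferative activity, read by MTT assay, with a stated time of 72 h (on this read-out lower numbers stand for stronger inhibition and higher numbers for weaker inhibition), compound 1 gives 5140 nM, the highest of the three numbers, and its steps to compound 3 and to compound 2 are beyond the scatter. For the measured compounds named here, compound 2 and compound 3 differ from compound 1 in more than one place, so no single-change step within the measured set can be read from them.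

The next compound, compound 4 `COc1cc2nccc(Oc3ccc(NC(=O)c4cc(-c5ccc(F)cc5)on4)cc3)c2cc1OC`, keeps the shared core of compound 1 and changes only the group on the carbonyl carbon: 5-(4-fluorophenyl)-1,2-oxazol-3-yl in place of 5-(4-fluorophenyl)-1,3,4-oxadiazol-2-yl on a carbonyl carbon.

Going by the values given here, no measured pair shows this change. The expectation for the step of a 1.5-fold lower number from compound 1 to compound 4 (0.17 log units; within the scatter) is therefore a small one, if anything toward a lower number, and not clearly beyond the scatter. Compound 4 is estimated at 3500 nM, with a range from 900 nM to 14000 nM.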

Compound 4, half-maximal inhibitory concentration: 40400 nM
The estimate for compound 4 lay 12-fold (1.06 log units) below the measured number; the measured number lies above the stated range.
By their numbers in this assay, from the lowest: compounds 2 and 3 (each within the scatter of the next); then compound 1; then compound 4.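

In this assay, 5-(4-fluorophenyl)-1,2-oxazol-3-yl in place of 5-(4-fluorophenyl)-1,3,4-oxadiazol-2-yl on a carbonyl carbon gives a 7.9-fold higher number from compound 1 to compound 4 (0.90 log units; beyond the scatter), so on this shared core the number responds to the identity of the five-membered ring. The two groups match in heavy-atom count and both keep the 4-fluorophenyl ring, so the step comes with a change in the hetero atoms of the five-membered ring. No measurement available here bears on the cause of this step.

Compound 2 and compound 3 differ from compound 4 in more than one place, so whether the step carries over to their cores cannot be read. Also open, on these data alone, is where a 5-(4-fluorophenyl)-1,3,4-thiadiazol-2-yl group on the same carbonyl carbon would fall relative to compound 1 and compound 4.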